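This account rests on a few compounds, and the source may have more. Where it says the series, first, only, none or still open, it means among the compounds named here.

Compound 1, `C=CC(=O)Nc1cccc(NC(=O)CSc2nc(Nc3cccc(Br)c3)c3ccccc3n2)c1`: 15000 nM
Compound 2, `C=CC(=O)Nc1cccc(NC(=O)CSc2nc(Nc3ccc(Br)cc3)c3ccccc3n2)c1`: 12400 nM

Both compounds share the same core and differ only in the bromophenyl group attached to a nitrogen on an aromatic ring. In a functional assay on PC-3 cells (Homo sapiens) for inhibition, read by MTT assay, with a stated time of 72 h (a higher number here means a weaker inhibitor, a lower number a stronger inhibitor), compound 1 gives 15000 nM, and compound 2 gives 12400 nM. Compound 2 has the lowest of the two numbers, but the step of a 1.2-fold lower number from compound 1 to compound 2 (0.08 log units; within the scatter) lies within the scatter, so the two compounds cannot be told apart on these data.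

Compound 3, `C=CC(=O)Nc1cccc(NC(=O)CSc2nc(Nc3ccc(F)c(Cl)c3)c3ccccc3n2)c1`, has not yet been measured in this assay. It differs from compound 2 in one place: 3-chloro-4-fluorophenyl in place of 4-bromophenyl on a nitrogen on an aromatic ring. Within the data shown here, the only measured step that bears on this change is a 1.2-fold lower number from compound 1 to compound 2 (0.08 log units; within the scatter), which shows that exchanging one bromophenyl for another on this nitrogen left the number essentially unchanged. Among the measured compounds shown here, no measured compound carries a 3-chloro-4-fluorophenyl group, so there is nothing to indicate a shift in either direction. The step from compound 2 to compound 3 is therefore expected to stay within the scatter, a 1.0-fold lower number from compound 2 to compound 3 (0.01 log units; within the scatter). Compound 3 is estimated at 12000 nM, with a range from 5000 nM to 30000 nM.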

Compound 3, half-maximal inhibitory concentration: > 50000 nM
Compound 3: only a limit was reported; the forecaster's own chance of this, stated with the estimate: 10%; at least 4.1-fold (0.61 log units) between middle value and limit.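

The group on this nitrogen is not indifferent to every exchange, although the earlier pair of bromophenyl compounds gave no sign of that. In this assay, 3-chloro-4-fluorophenyl in place of 4-bromophenyl gives an at least 4.0-fold higher number from compound 2 to compound 3 (0.60 log units; beyond the scatter), and the same group in place of 3-bromophenyl gives an at least 3.3-fold higher number from compound 1 to compound 3 (0.52 log units; beyond the scatter), so compound 3 is the weaker inhibitor in both comparisons. The reading for compound 3 is a limit of the assay and not a number, which makes both steps minimum sizes only: the limit of > 50000 nM in this assay, at which 1 of the 3 values shown sits.

The change removes the bromine and brings in a chlorine and a fluorine in a single move, so these compounds cannot show which of these differences matters, and a phenyl carrying only a chlorine or only a fluorine on this nitrogen would help to separate them. From the compounds shown here alone, how far compound 3 lies past its limit also stays open, as does the effect of a phenyl with no halogen at all or one carrying a methoxy group.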